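Swapping a chlorophenyl for an aminopyridyl on a shared core

The source may hold more compounds than are shown below. What is called first, only, known or untested is meant among the compounds shown, and "the series" means these compounds.

Of the compounds shown here, three sharing one core have been measured in a functional assay on SGC-7901 cells (Homo sapiens) for cytotoxicity, read by MTT assay, with a stated time of 48 h; on this read-out higher numbers stand for weaker inhibition and lower numbers for stronger inhibition. Compound 1 `Cc1ncc([N+](=O)[O-])n1CCSc1nnc(-c2ccc(N)cc2)o1` gives 31700 nM in this assay. Compound 2 `CCOc1ccccc1-c1nnc(SCCn2c([N+](=O)[O-])cnc2C)o1` gives 30300 nM in this assay. Compound 3 `Cc1ncc([N+](=O)[O-])n1CCSc1nnc(-c2ccccc2Cl)o1` gives 32600 nM in this assay, and its number sits alongside those of compounds 1 and 2: the step of a 1.0-fold higher number from compound 1 to compound 3 (0.01 log units; within the scatter) and the step of a 1.1-fold higher number from compound 2 to compound 3 (0.03 log units; within the scatter) are both within the scatter, so the three cannot be told apart.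

Compound 4 `Cc1ncc([N+](=O)[O-])n1CCSc1nnc(-c2cnccc2N)o1` has not yet been measured. It differs from compound 3 in one place: 4-aminopyridin-3-yl in place of 2-chlorophenyl on an aromatic carbon. Both measured steps bear on this change, since each also swaps the group at that same place, and neither moved the number beyond the scatter. On that basis no step beyond the scatter is expected in this assay, in either direction, for the step of a 1.0-fold lower number from compound 3 to compound 4 (0.01 log units; within the scatter). Compound 4 is therefore estimated at 32000 nM in this assay, with a range from 16000 nM to 64000 nM.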

Compound 4, half-maximal inhibitory concentration: 34500 nM
Estimate against measurement, compound 4: 1.1-fold (0.03 log units) below, within the range that was stated.
By their numbers in this assay, from the lowest: compounds 2, 1, 3 and 4 (each within the scatter of the next).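

For the compounds shown here, compound 4 is the first in this set whose group at this position has a hetero atom in its six-membered aromatic ring, and in this assay that change gives a 1.1-fold higher number from compound 3 to compound 4 (0.02 log units; within the scatter). The comparison with the amine-bearing group of compound 1 gives a 1.1-fold higher number from compound 1 to compound 4 (0.04 log units; within the scatter), so this position has now taken a ring with a hetero atom, along with added hydrogen-bond donor and acceptor counts relative to compound 3, without a step beyond the scatter. Nothing available here explains why the number stays put.

All the groups shown at this position are six-membered aromatic rings, so it remains open whether a carboxylic acid on that ring, or a saturated ring such as piperidine in its place, would move the number. The compounds also leave open whether changes elsewhere on the shared core would do so.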